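The compounds below may be only part of what the source reports. "The series", "measured", "known", "first", "only" and "open" are said of these compounds alone.

Of the compounds shown here, two have been measured in an assay on HT-29 cells for inhibition of Serine-protein kinase ATM (Homo sapiens), read by fluorescence, with a stated time of 1 h; a higher number here means a weaker inhibitor, a lower number a stronger inhibitor. Compound 1 `COCc1ccc(-c2ccc3nnc(C(N)=O)c(N[C@@H](C)C4CCOCC4)c3c2)cn1` gives 140 nM. Compound 2 `COCc1ccc(-c2ccc3nnc(C(N)=O)c(N[C@@H](C)c4ccn(C)n4)c3c2)cn1` gives 260 nM. Going by the values given here, compound 2 thus holds the higher of the two numbers, but the only step in the set, a 1.9-fold higher number from compound 1 to compound 2 (0.27 log units; within the scatter), lies within the scatter, so the two values cannot be ordered against each other.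

Compound 3 `COCc1ccc(-c2ccc3nnc(C(N)=O)c(N[C@@H](C)c4nn(C)cc4C)c3c2)cn1` is the next structure, differing from compound 2 as follows: methyl in place of hydrogen on an aromatic carbon. Among the compounds with values here, no measured step bears on this change. Within the data shown here, the one step available, a 1.9-fold higher number from compound 1 to compound 2 (0.27 log units; within the scatter), exchanges the whole group on the saturated chain carbon and carries no information on a methyl placed on the five-membered ring. With nothing comparable measured, the expectation in this assay is no step beyond the scatter. Compound 3 is expected to give 260 nM, with a range from 90 nM to 750 nM. Among the measured compounds shown here, the estimated step, no change at the digits printed from compound 2 to compound 3 (within the scatter), is set at no change, and the range is kept wide; the added methyl has no measured counterpart among the compounds so far.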

Compound 3, half-maximal inhibitory concentration: 44 nM
The estimate for compound 3 lay 5.9-fold (0.77 log units) above the measured number, and the stated range ends above it.
By their numbers in this assay, from the lowest: compound 3; then compounds 1 and 2 (each within the scatter of the next).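

Working from this assay, methyl in place of hydrogen on the aromatic carbon next to the ring atom that bears a large group gives the first single-place step in the series that lies beyond the scatter (a 5.9-fold lower number from compound 2 to compound 3 (0.77 log units; beyond the scatter)), so this position of the five-membered aromatic ring responds to the addition of just one carbon. The 1,4-dimethyl-1H-pyrazol-3-yl group also separates from oxan-4-yl (a 3.2-fold lower number from compound 1 to compound 3 (0.50 log units; beyond the scatter)), whereas the values of compound 1 and compound 2 could not be ordered, so among these three compounds only the group carrying the added methyl stands apart from oxan-4-yl. No measured evidence here accounts for the size of this step.

Still open, from the compounds shown here alone, is whether the step is particular to methyl on this aromatic carbon, which an ethyl group, a chlorine atom or a methoxy group there would test. Also open, going by these compounds, is whether the methyl on the ring nitrogen contributes to the result, which the 4-methyl-1H-pyrazol-3-yl group, with hydrogen on that nitrogen, would address.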